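The source may hold more compounds than are shown below. What is called first, only, known or untested is meant among the compounds shown, and "the series" means these compounds.

Compound 1 `COc1c(/C=C2/C(=O)Nc3ccccc32)c2ccccc2n1-c1ccccc1` is the reference point of this set. In a functional assay on cells (Cancer cell lines, Homo sapiens) for cytotoxicity, with a stated time of 48 h (on this read-out higher numbers stand for weaker inhibition of growth and lower numbers for stronger inhibition of growth), compound 1 gives 1230 nM. Compound 3 `COc1c(/C=C2/C(=O)Nc3ccc(Cl)cc32)c2ccccc2n1-c1ccccc1` differs from compound 1 by chloro in place of hydrogen on an aromatic carbon. In this assay compound 3 gives 4270 nM, which makes the step of a 3.5-fold higher number from compound 1 to compound 3 (0.54 log units; beyond the scatter).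

Compound 2 `O=C1Nc2ccccc2/C1=C\c1c(Cl)n(CCCc2ccccc2)c2ccccc12` is built on a different core; the difference between the two cores is not broken down here. In this assay compound 2 gives 10000 nM, the highest of the three numbers, beyond the scatter from compound 3 and from compound 1.

Compound 4 `O=C1Nc2ccc(Cl)cc2/C1=C\c1c(Cl)n(CCCc2ccccc2)c2ccccc12` has not been measured yet. Among the measured compounds shown here, it differs from compound 2 by chloro in place of hydrogen on an aromatic carbon, the same change, at the same place, as the one that separates compound 1 from compound 3. If that change keeps its size on the second core, the step from compound 2 to compound 4 is expected to be a 3.0-fold higher number from compound 2 to compound 4 (0.48 log units; beyond the scatter), resting on a 3.5-fold higher number from compound 1 to compound 3 (0.54 log units; beyond the scatter). The starting number of compound 2, 10000 nM, is already the highest of the three measured numbers. Compound 4 is therefore estimated at 30000 nM, with a range from 9000 nM to 90000 nM.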

Compound 4, concentration for 50% growth inhibition: 2190 nM
Compound 4: the middle estimate sits 14-fold (1.14 log units) above what was measured, outside the stated range (below it).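

On the core of compound 2, chloro in place of hydrogen on the aromatic carbon gives a 4.6-fold lower number from compound 2 to compound 4 (0.66 log units; beyond the scatter), so in this assay the change does not carry over from the core of compound 1 in either size or direction: the same change on two cores in this assay, a 3.5-fold higher number (0.54 log units; beyond the scatter) from compound 1 to compound 3 and a 4.6-fold lower number (0.66 log units; beyond the scatter) from compound 2 to compound 4, 16-fold (1.20 log units) apart, beyond the scatter of two such steps

This shows that, for these two cores, the effect of this chloro depends on the core that carries it, and a step measured on one core did not predict the step on the other. It does not show which part of the difference between the cores reverses the step, and one pair on each core gives no rule for any further core.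

The compounds shown leave open whether another group in the same place, such as fluoro, methyl or an amine, would also move in opposite directions on the two cores. Among the compounds shown here, they also leave open whether the chloro step would change if a shorter chain replaced the one on compound 2.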